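Removing one methyl from an inactive-looking compound

The source may report more compounds than this note shows. Statements on the series, on what has been measured and on what is new or still open speak of the compounds shown alone.

Measurements in a functional assay on MDA-MB-231 cells (Homo sapiens) for antiproliferative activity, read by MTT assay (a lower number here means a stronger inhibitor, a higher number a weaker inhibitor), cover three related compounds. Compound 1 `CCCC/C=C\CCCCCCCCCc1cc(=O)c2c(O)cc(O)c(C)c2o1` gives 6790 nM, and compound 2 `CCCCC/C=C\C/C=C\CCCCCCCc1cc(=O)c2c(O)cc(O)c(C)c2o1` gives 6790 nM. Compound 3 `CCCCCCCCCCCCCCCc1cc(=O)c2c(O)c(C)c(O)c(C)c2o1` gives > 87000 nM, which is a limit and not a number.

The unmeasured compound 4 `CCCCCCCCCCCCCCCc1cc(=O)c2c(O)cc(O)c(C)c2o1` differs from compound 3 by a single swap: hydrogen in place of methyl on an aromatic carbon. The swap sits on an aromatic carbon, ortho to two hydroxy groups. Compound 4 keeps the saturated chain of compound 3 but has hydrogen on this carbon, as do compound 1 and compound 2.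

Among the measured compounds shown here, only one measured step exists, and it alters the chain rather than this carbon: no change at the digits printed from compound 1 to compound 2 (within the scatter). That step shows two different chains giving the same reading on the core with hydrogen, but neither of those chains is the saturated one. For the measured compounds named here, no measured step isolates the methyl swap itself, so any expectation here is loose.

Compound 4 is still expected to read closer to compound 1 at 6790 nM, since it shares that core. The expected change is an at least 7.2-fold lower number from compound 3 to compound 4 (0.86 log units; beyond the scatter), towards a stronger inhibitor in this assay. For compound 4 the estimated value is 12000 nM, with an expected range from 4000 nM to 50000 nM.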

Compound 4, half-maximal inhibitory concentration: 6790 nM
Compound 4: middle estimate off by 1.8-fold (0.25 log units), on the high side; the measured number falls inside the stated range.
By their numbers in this assay, from the lowest: compounds 1, 2 and 4 (each within the scatter of the next). At a limit, above all of these: compound 3.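

Taking the methyl off this aromatic carbon, ortho to two hydroxy groups, gives an at least 12-fold lower number from compound 3 to compound 4 (1.10 log units; beyond the scatter) in this assay, and this is the only measured step that isolates a change at this position. The reading for compound 3 is a limit and not a number, so the true size of this step remains unknown: the limit of > 87000 nM in this assay, at which 1 of the 4 values shown sits.

With hydrogen on this carbon, the saturated chain reads like the two unsaturated chains, with no change at the digits printed from compound 2 to compound 4 (within the scatter) and no change at the digits printed from compound 1 to compound 4 (within the scatter), so among these three compounds the chain makes no difference beyond the scatter, and the saturated chain alone does not separate compound 3 from compound 4.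

From the compounds shown here alone, whether another group on this carbon, such as a chlorine atom or a methoxy group, would behave like the methyl stays open, as does whether the methyl would have the same effect on the unsaturated chains of compound 1 and compound 2. Going by these compounds, how a much shorter chain, or a chain ending in a carboxylic acid, would read on the shared core also stays open.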